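Swapping chloro for trifluoromethyl on the phenylpiperazine

The source may report more compounds than this note shows. Statements on the series, on what has been measured and on what is new or still open speak of the compounds shown alone.

Of the compounds shown here, three sharing one core have been measured in an assay on membranes from CHO-K1 cells for displacement of a labelled ligand from 5-hydroxytryptamine receptor 7 (Homo sapiens), read by scintillation counting; on this read-out lower numbers stand for stronger inhibition and higher numbers for weaker inhibition. Compound 1 `COc1cc2ncnc(N3CCC(CN4CCN(c5ccccc5)CC4)C3)c2cc1OC` gives 251 nM, compound 2 `COc1cc2ncnc(N3CCC(CN4CCN(c5ccccc5OC)CC4)C3)c2cc1OC` gives 56.2 nM, and compound 3 `COc1cc2ncnc(N3CCC(CN4CCN(c5cccc(Cl)c5)CC4)C3)c2cc1OC` gives 372 nM. Compound 3 thus stands highest of the three numbers in this assay, close to compound 1 and farthest from compound 2.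

Compound 4 `COc1cc2ncnc(N3CCC(CN4CCN(c5cccc(C(F)(F)F)c5)CC4)C3)c2cc1OC` differs from compound 3 by trifluoromethyl in place of chloro on an aromatic carbon. For the measured compounds named here, no measured pair here exchanges chloro for trifluoromethyl, so only indirect guidance exists. The nearest step is a 1.5-fold higher number from compound 1 to compound 3 (0.17 log units; within the scatter), showing that adding chloro at that ring position barely moved the number. The other step, a 6.6-fold higher number from compound 2 to compound 3 (0.82 log units; beyond the scatter), shows the larger change that comes from altering the substitution pattern on the phenyl ring. Since compound 4 keeps the same position and merely changes one group for another of similar kind, the expected step of a 1.1-fold higher number from compound 3 to compound 4 (0.03 log units; within the scatter) is small, likely within the scatter, with no clear direction. Compound 4 is therefore estimated at 400 nM, between 150 nM and 1100 nM.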

Compound 4, inhibition constant: 229 nM
For compound 4 the middle estimate is 1.7-fold (0.24 log units) above the measured one; measured number inside the range.
By their numbers in this assay, from the lowest: compound 2; then compounds 4, 1 and 3 (each within the scatter of the next).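

Putting trifluoromethyl in place of chloro at this place on the ring gives a 1.6-fold lower number from compound 3 to compound 4 (0.21 log units; within the scatter) in this assay and stays within the scatter, so the larger group, with its four heavy atoms against one, cannot be told apart from chloro here. Set against the plain phenyl ring, the same group gives a 1.1-fold lower number from compound 1 to compound 4 (0.04 log units; within the scatter) and is also within the scatter, so neither of these two groups at this place separates from hydrogen. The 2-methoxyphenyl group still stands apart, with a 4.1-fold higher number from compound 2 to compound 4 (0.61 log units; beyond the scatter) lying beyond the scatter.

Going by these compounds, whether an amine or a hydroxyl group at this place on the ring would move the number beyond the scatter stays open. Nothing at hand bears on what lies behind these numbers.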